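Swapping the Carbamoyl for a Protected Aminomethyl Group

The compounds below may be only part of what the source reports. "The series", "measured", "known", "first", "only" and "open" are said of these compounds alone.

Compound 1 `CC(C)(C)c1ccc(C(=O)N2CCC3(CC2)C(=O)N(CC(=O)N2CCCC(C(N)=O)C2)CN3c2ccccc2)cc1` is one of three close relatives sharing a spiro-fused core and a tert-butylbenzoyl group; it was tested in an assay on HEK293 cells for displacement of a labelled ligand from NPC1-like intracellular cholesterol transporter 1 (Homo sapiens); a higher number here means a weaker inhibitor, a lower number a stronger inhibitor. Compound 1 gives 16900 nM, the highest of the three numbers. Compound 2 `CC(C)(C)c1ccc(C(=O)N2CCC3(CC2)C(=O)N(CC(=O)N2CCC(O)CC2)CN3c2ccccc2)cc1` carries a 4-hydroxypiperidin-1-yl group instead and gives 4700 nM, so that a 3.6-fold lower number from compound 1 to compound 2 (0.56 log units; beyond the scatter). Compound 3 `CC(C)(C)c1ccc(C(=O)N2CCC3(CC2)C(=O)N(CC(=O)NCCCCN)CN3c2ccccc2)cc1` carries a (4-aminobutyl)amino group and gives 14500 nM, with a 1.2-fold lower number from compound 1 to compound 3 (0.07 log units; within the scatter).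

Compound 4 `CC(C)(C)OC(=O)NCC1CCCN(C(=O)CN2CN(c3ccccc3)C3(CCN(C(=O)c4ccc(C(C)(C)C)cc4)CC3)C2=O)C1` keeps the piperidine ring of compound 1 but alters its substituent: ((tert-butoxycarbonyl)amino)methyl in place of carbamoyl on a saturated ring carbon. Going by the values given here, no measured step shows this particular exchange. The two steps that do change the same part of the molecule, from compound 1 to compound 2 and from compound 1 to compound 3, move the number only modestly or not beyond the scatter. Compound 4 is therefore expected to land near compound 1, and a 1.4-fold lower number from compound 1 to compound 4 (0.15 log units; within the scatter) is expected to stay small. The estimate for compound 4 is 12000 nM, within a range from 4000 nM to 36000 nM.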

Compound 4, half-maximal inhibitory concentration: 9500 nM
Compound 4: middle estimate off by 1.3-fold (0.10 log units), on the high side, and the stated range covers the measured number.
By their numbers in this assay, from the lowest: compound 2; then compounds 4, 3 and 1 (each within the scatter of the next).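

Keeping the piperidine ring of compound 1 and changing only the group on its saturated ring carbon gives a 1.8-fold lower number from compound 1 to compound 4 (0.25 log units; within the scatter) and so isolates this one position, whereas the earlier steps replaced the whole group on the carbonyl carbon. Here, ((tert-butoxycarbonyl)amino)methyl with 9 heavy atoms stands in place of carbamoyl with 3, and this much larger group leaves the number within the scatter. Nothing measured here gives a reason for this result.

Going by these compounds, what a plain aminomethyl group, carrying a free amine, or a carboxylic acid would give on this same ring carbon remains open. A longer chain at this carbon is also untested among the compounds shown, so how much more bulk the position accepts is unknown.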